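The compounds below may be only part of what the source reports. "The series", "measured", "known", "first", "only" and "open" are said of these compounds alone.

Three compounds have numbers in an assay on isolated protein for inhibition of bone morphogenetic protein 1 (Homo sapiens); a higher number here means a weaker inhibitor, a lower number a stronger inhibitor. Compound 1 `CC[C@H](C)[C@H](NS(=O)(=O)c1cc(Cl)ccc1Cl)C(=O)N[C@@H](CNC(=O)OCc1ccccc1)C(=O)NO` gives 65 nM, compound 2 `CC[C@@H](C)[C@@H](NC(=O)OCc1ccccc1)C(=O)NCC(NCc1ccccc1)C(=O)NO` gives 94 nM, and compound 3 `CNC(=O)C1CCCN1C(=O)[C@H](CCC(N)=O)NC(=O)[C@H](CC(=O)O)CC(=O)NO` gives 22000 nM, the highest of the three and beyond the scatter against both of the others, so compound 3 is the weakest inhibitor of this set.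

Compound 4 `CNC(=O)[C@H](CCC(N)=O)NC(=O)[C@H](CC(=O)O)CC(=O)NO` is compound 3 shortened: methylamino in place of 2-(methylcarbamoyl)pyrrolidin-1-yl on a carbonyl carbon. For the measured compounds named here, no pair of measured compounds with this single change exists, so the expected step rests on the change alone. Removing part of the chain end of compound 3 is expected to move this assay toward a higher number by a moderate step, a 2.0-fold higher number from compound 3 to compound 4 (0.31 log units; beyond the scatter), with a real chance that only a limit is reported. For compound 4 the estimate is 45000 nM, within a range of 12000 nM to 170000 nM.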

Compound 4, half-maximal inhibitory concentration: 68000 nM
Compound 4: the middle estimate sits 1.5-fold (0.18 log units) below what was measured, within the range that was stated.
By their numbers in this assay, from the lowest: compounds 1 and 2 (each within the scatter of the next); then compound 3; then compound 4.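

For the compounds shown here, replacing 2-(methylcarbamoyl)pyrrolidin-1-yl with methylamino on a carbonyl carbon gives, in this assay, a 3.1-fold higher number from compound 3 to compound 4 (0.49 log units; beyond the scatter), the first single-place comparison. The larger group therefore has a modest, measurable bearing on the number at this position, and the shortened compound 4 still gives a value rather than a limit. Nothing available explains the step. From the compounds shown here alone, whether the ring itself matters remains open, since a longer open chain ending in methylcarbamoyl would be needed to separate ring from chain length. Going by these compounds, whether an amine or a carboxylic acid at this place would lower the number also remains open.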